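Swapping 2-fluorophenyl for 4-fluorophenyl

This account rests on a few compounds, and the source may have more. Where it says the series, first, only, none or still open, it means among the compounds named here.

Measured in a functional assay on SGC-7901 cells (Homo sapiens) for antiproliferative activity, read by MTT assay, with a stated time of 48 h; a lower number here means a stronger inhibitor, a higher number a weaker inhibitor:
- compound 1 `CCOc1ccc(-c2nnc(SCc3ccc(Cl)nc3)o2)cc1` gives 4.97 ug/mL
- compound 2 `Fc1ccccc1-c1nnc(SCc2ccc(Cl)nc2)o1` gives 9.12 ug/mL

Compound 2 and compound 1 lie within the usual scatter of each other, so neither stands apart on these numbers. Compound 3 `Fc1ccc(-c2nnc(SCc3ccc(Cl)nc3)o2)cc1` has 4-fluorophenyl in place of 2-fluorophenyl on an aromatic carbon and has not yet been measured. Within the data shown here, no measured pair shows this change, so in this assay no step beyond the scatter is expected, in either direction. The expected size of the change is a 1.3-fold lower number from compound 2 to compound 3 (0.11 log units; within the scatter), a small one. For compound 3 the estimate is 7 ug/mL, with an expected range from 3 ug/mL to 16 ug/mL.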

Compound 3, half-maximal inhibitory concentration: 3.67 ug/mL
Compound 3: the middle estimate sits 1.9-fold (0.28 log units) above what was measured, and the stated range covers the measured number.
By their numbers in this assay, from the lowest: compounds 3, 1 and 2 (each within the scatter of the next, the first and the last beyond it).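

In this assay, 4-fluorophenyl in place of 2-fluorophenyl gives a 2.5-fold lower number from compound 2 to compound 3 (0.40 log units; beyond the scatter) with no change in the atoms present, so where the fluorine sits on this phenyl ring counts here. Fluoro in place of ethoxy gives a 1.4-fold lower number from compound 1 to compound 3 (0.13 log units; within the scatter) and so does not separate these two groups.

As far as these compounds go, how an amine or a carboxylic acid on this phenyl ring would compare stays open. Nothing available here explains why the place of the fluorine matters.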